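A few compounds are considered here, and "the series" means these few. Any claim that something is new, unique, unknown or untested is made for them only; others in the source may bear on it.

Measured in a functional assay on NCI-H226 cells (Homo sapiens) for cytotoxicity, read by sulforhodamine B assay, with a stated time of 48 h, tested at 10 uM; a lower number here means a stronger effect, a higher number a weaker effect of the compound at the concentration tested:
compound 1 `COc1cc(-c2cc(/C=C/C(=O)c3ccc(N)cc3)[nH]n2)cc(OC)c1OC`: -73%
compound 2 `COc1ccc(-c2cc(/C=C/C(=O)c3ccc(N)cc3)[nH]n2)cc1`: -29%
compound 3 `COc1ccc(C(=O)/C=C/c2cc(-c3cc(OC)c(OC)c(OC)c3)n[nH]2)cc1`: -59%

Compound 3 stands second highest of the three numbers. Its nearest neighbour is compound 1, separated by a number 14 percentage points higher from compound 1 to compound 3 (beyond the scatter), a modest rise beyond the scatter; compound 2 lies furthest, with a higher number than compound 3.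

Compound 4 `COc1cc(-c2cc(/C=C/C(=O)c3ccc(F)c(F)c3)[nH]n2)cc(OC)c1OC` differs from compound 3 by 3,4-difluorophenyl in place of 4-methoxyphenyl on a carbonyl carbon. Among the compounds with values here, the only measured step, a number 14 percentage points higher from compound 1 to compound 3 (beyond the scatter), concerns a different substituent on the ring attached to that carbonyl carbon and shows that changing this ring shifts the number modestly; it does not cover the present swap, so no direction is fixed. The expected step of a number 4 percentage points higher from compound 3 to compound 4 (within the scatter) is therefore small and uncertain in sign. Compound 4 is estimated at -55%, within -80% to -25%.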

Compound 4, a percentage reported as activity, at one concentration (the size of the read-out at that concentration, not a potency): 16%
Compound 4: the middle estimate sits 71 percentage points below what was measured; measured number above the stated range.
By their numbers in this assay, from the lowest: compound 1; then compound 3; then compound 2; then compound 4.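

In this assay, within the data shown here, the group on the carbonyl carbon matters far more than the one earlier step indicated: 3,4-difluorophenyl in place of 4-methoxyphenyl gives a number 75 percentage points higher from compound 3 to compound 4 (beyond the scatter), and in place of 4-aminophenyl gives a number 89 percentage points higher from compound 1 to compound 4 (beyond the scatter). Both steps are large beside the modest a number 14 percentage points higher from compound 1 to compound 3 (beyond the scatter), and only compound 4 has a positive number, 16%. Nothing available explains this shift.

Still open, going by these compounds, is whether a single fluorine or a chlorine on this ring would give a step of similar size. On these data alone, it is also open whether 3,4-difluorophenyl acts alike on the core of compound 2.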